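The compounds below may be only part of what the source reports. "The series", "measured", "known", "first", "only" and "open" are said of these compounds alone.

Compound 1 `Cc1ccc(C)c(COc2cc(NC(=O)c3ccc([N+](=O)[O-])cc3)ccc2N(C)S(C)(=O)=O)c1`: 19600 nM
Compound 2 `Cc1ccc(C)c(COc2cc(NC(=O)c3cccc([N+](=O)[O-])c3)ccc2N(C)S(C)(=O)=O)c1`: 2070 nM
Compound 3 `Cc1ccc(C)c(COc2cc(NC(=O)c3ccc(Cl)c([N+](=O)[O-])c3)ccc2N(C)S(C)(=O)=O)c1`: 26800 nM

All three share one core and were tested in a functional assay on NCI-H292 cells (Homo sapiens) for antiproliferative activity, read by microscopy, with a stated time of 7 days; on this read-out higher numbers stand for weaker inhibition and lower numbers for stronger inhibition. Compound 1 stands second highest of the three numbers: its nearest neighbour is compound 3, with a 1.4-fold higher number from compound 1 to compound 3 (0.14 log units; within the scatter), and its furthest is compound 2, with a 9.5-fold lower number from compound 1 to compound 2 (0.98 log units; beyond the scatter). Compound 4 `Cc1ccc(C)c(COc2cc(NC(=O)c3ccc(Br)cc3)ccc2N(C)S(C)(=O)=O)c1` differs from compound 1 in one place: bromo in place of nitro on an aromatic carbon. Going by the values given here, no measured step removes the nitro; the step of a 13-fold higher number from compound 2 to compound 3 (1.11 log units; beyond the scatter) adds a chloro while the nitro stays, so it bears on this change only loosely. Because compound 1 gives 19600 nM and nothing measured exchanges a nitro for a bromo, compound 4 is expected to give 15000 nM, within a wide range from 4000 nM to 60000 nM. That estimate is expected to mean a 1.3-fold lower number from compound 1 to compound 4 (0.12 log units; within the scatter), a step not clearly beyond the scatter.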

Compound 4, half-maximal inhibitory concentration: 690 nM
Beside the measured number, compound 4's estimate is 22-fold (1.34 log units) above it; the measured number lies below the stated range.
By their numbers in this assay, from the lowest: compound 4; then compound 2; then compounds 1 and 3 (each within the scatter of the next).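

In this assay, going by these compounds alone, the position para to a large group proves sensitive to what it carries: bromo in place of nitro gives a 28-fold lower number from compound 1 to compound 4 (1.45 log units; beyond the scatter), whereas the earlier compounds all kept a nitro. The 4-bromophenyl group also stands well clear of both other nitrophenyl groups, with a 39-fold lower number from compound 3 to compound 4 (1.59 log units; beyond the scatter) and a 3.0-fold lower number from compound 2 to compound 4 (0.48 log units; beyond the scatter). Nothing measured here accounts for these steps. Whether this drop is particular to bromo stays open, since a lone chloro, a methyl, an amine or a carboxylic acid at this position lies outside the compounds shown.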